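A few compounds are considered here, and "the series" means these few. Any claim that something is new, unique, unknown or untested is made for them only; others in the source may bear on it.

In a functional assay on MT2 cells (Homo sapiens) for cytotoxicity, read by MTT assay (on this read-out higher numbers stand for lower toxicity in this test and lower numbers for higher toxicity in this test), compound 1 (`CCCc1ccc(Nc2nccs2)cc1OCC=C(C)C`) gives 23000 nM and compound 2 (`Clc1ccc(Nc2nccs2)cc1OCc1ccoc1`) gives 26000 nM, so compound 2 stands level with compound 1, within the usual scatter. Compound 3 (`Clc1ccc(Nc2nccs2)cc1OCc1nccs1`) differs from compound 2 in one place: 1,3-thiazol-2-yl in place of furan-3-yl on a saturated chain carbon bound to an oxygen on an aromatic ring. Among the compounds with values here, no step between measured compounds shows what such a swap does, so no shift beyond the scatter is expected in this assay, and no direction is assumed. The expected change is a 1.0-fold lower number from compound 2 to compound 3 (0.02 log units; within the scatter). For compound 3 the estimated value is 25000 nM, with an expected range of 10000 nM to 60000 nM.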

Compound 3, half-maximal cytotoxic concentration: 20000 nM
Compound 3: middle estimate off by 1.3-fold (0.10 log units), on the high side; low and high end bracket the measured number.
By their numbers in this assay, from the lowest: compounds 3, 1 and 2 (each within the scatter of the next).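

In this assay, within the data shown here, the step at this position reads a 1.3-fold lower number from compound 2 to compound 3 (0.11 log units; within the scatter) and lies within the scatter, the first measured swap of one five-membered aromatic ring for another on the saturated chain carbon bound to an oxygen on an aromatic ring. Furan-3-yl and 1,3-thiazol-2-yl therefore stand level here, despite their different hetero atoms. Nothing measured bears on why this is so. As far as these compounds go, whether the number stays level with an amine, a carboxylic acid or a longer chain at this place remains open.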